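A Pyridyl Swap Across Two Cores in Acid Dissociation

The compounds below may be only part of what the source reports. "The series", "measured", "known", "first", "only" and "open" are said of these compounds alone.

In a physicochemical assay for acid dissociation, the measured compounds gave the following:

Compound 1, `COc1ccc(-c2c(C)nc3c(NCc4ccc(C(N)=O)cc4)cc(C)cn23)cc1OC`, gave 6.6.
Compound 2, `COc1ccc(-c2c(C)nc3c(NCc4cccnc4)cc(C)cn23)cc1OC`, gave 6.5.
Compound 3, `COc1ccc(-c2c(C)nn3c(NCc4ccc(C(N)=O)cc4)nc(C)cc23)cc1OC`, gave 3.8.

Compound 1 and compound 2 share one core and differ only in one place: pyridin-3-yl in place of 4-carbamoylphenyl on a saturated chain carbon bound to a nitrogen on an aromatic ring. That change gave a number 0.10 log units lower from compound 1 to compound 2 (within the scatter), so the two values in this assay lie together within the scatter, and no order between them is claimed.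

Compound 3 carries a different core. The difference between the core of compound 1 and the core of compound 3 is not broken down here. Compound 3 stands lowest of the three numbers; its nearest neighbour in this assay is compound 2, and the gap to it, like the gap to compound 1, lies beyond the scatter.

Compound 4, `COc1ccc(-c2c(C)nn3c(NCc4cccnc4)nc(C)cc23)cc1OC`, is not yet measured. It stands to compound 3 as compound 2 stands to compound 1: pyridin-3-yl in place of 4-carbamoylphenyl on a saturated chain carbon bound to a nitrogen on an aromatic ring. The place is the same in both pairs, so this is the same change, now made on the core of compound 3.

For compound 4 the estimated step is a number 0.10 log units lower from compound 3 to compound 4 (within the scatter), which rests on a number 0.10 log units lower from compound 1 to compound 2 (within the scatter). Compound 4 is therefore expected to give 3.7, with a range from 3.3 to 4.1, because compound 3 gave 3.8 and the same change elsewhere stayed within the scatter.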

Compound 4, acid dissociation constant: 2.8
Estimate against measurement, compound 4: 0.90 log units above; measured number outside the range, below it.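

In this assay, the replacement of 4-carbamoylphenyl by pyridin-3-yl gave a number 1.00 log units lower from compound 3 to compound 4 (beyond the scatter) on the core of compound 3, while the same replacement at the same place gave a number 0.10 log units lower from compound 1 to compound 2 (within the scatter) on the core of compound 1. This shows that, in these two pairs, a change that stayed within the scatter on one core did not stay there on the other, so the step seen on the core of compound 1 did not carry over in size to the core of compound 3; it does not show a rule for any further core or any other group, since it rests on a single change read on just two cores. No measurement offered here bears on why the two steps differ, and the values themselves give no reason for it.

The compounds shown leave open whether a similar difference between the two cores would appear with other groups at this place, such as pyridin-4-yl, a phenyl ring carrying a carboxylic acid or an amine, or a longer chain on the same nitrogen. They also leave open which atom gives up the proton in each of the four compounds.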